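A few compounds are considered here, and "the series" means these few. Any claim that something is new, unique, unknown or untested is made for them only; others in the source may bear on it.

Measured so far:
compound 1, `CS/C(=N\C(=O)c1cc2ccccc2s1)NC(=O)c1cc2ccccc2s1` — 98600 nM
compound 2, `C[Se]/C(=N\C(=O)c1cccs1)NC(=O)c1cccs1` — > 100000 nM

In a functional assay on K562 cells (Homo sapiens) for cytotoxicity, read by MTT assay, with a stated time of 72 h (a lower number here means that less compound is tolerated, a higher number that more compound is tolerated), compound 1 gives 98600 nM. For compound 2 the assay reports only a limit, > 100000 nM (the limit of > 100000 nM in this assay, at which 1 of the 2 values shown sits). Compound 2 therefore stands at the more-tolerated end of the two values recorded, with no number of its own.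

Compound 3, `O=C(/N=C(/NC(=O)c1cccs1)[Se]Cc1ccccc1)c1cccs1`, differs from compound 2 by phenyl in place of hydrogen on a saturated chain carbon bound to a selenium atom. Among the measured compounds shown here, no measured pair shows this kind of change, so the size of the step is open; a modest move toward less tolerated compound is expected, an at least 1.4-fold lower number from compound 2 to compound 3 (0.15 log units; that floor lies within the scatter), with a fair chance that only a limit results again. Compound 3 is estimated at 70000 nM, in the range 25000 nM to 200000 nM.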

Compound 3, concentration lethal to 50% of the cells: 87400 nM
Compound 3: the middle estimate sits 1.2-fold (0.10 log units) below what was measured; low and high end bracket the measured number.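

Phenyl in place of hydrogen on a saturated chain carbon bound to a selenium atom gives the first measured step at this position in this assay, with an at least 1.1-fold lower number from compound 2 to compound 3 (0.05 log units; that floor lies within the scatter). Compound 3 has a number of its own, so the methyl to benzyl change brings this position into the measurable range. The step remains only a floor, and its starting point is a limit for compound 2: the limit of > 100000 nM in this assay, at which 1 of the 3 values shown sits.

Going by these compounds, the true size of the step remains open. So does the reading for a longer chain or a carboxylic acid at this carbon.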